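Amide substituent variation on a weakly active compound

The source may hold more compounds than are shown below. What is called first, only, known or untested is meant among the compounds shown, and "the series" means these compounds.

Compound 1 `CCC1C(=O)N(C)c2cnc(-n3ccc4cc(C(=O)NC)ccc43)nc2N1c1ccn(C)n1` is the weakest-looking member of the three compounds with numbers. In a functional assay on K562 cells (Homo sapiens) for antiproliferative activity, read by CCK-8 assay, with a stated time of 72 h (on this read-out higher numbers stand for weaker inhibition of growth and lower numbers for stronger inhibition of growth), compound 1 gives 13300 nM, the highest of the three values. Compound 3 `CCC1C(=O)N(C)c2cnc(Nc3ccc(S(=O)(=O)NCC(C)C)cc3)nc2N1c1ccn(C)n1` gives 7300 nM, a gap to compound 1 that sits within the scatter, so the two are not distinguished here. Within the data shown here, compound 2 `CC[C@@H]1C(=O)N(C)c2cnc(Nc3ccc(S(N)(=O)=O)cc3)nc2N1C1CCCC1` gives 470 nM, well beyond the scatter from compound 1, although compound 2 differs from compound 1 in several places and no single step connects them.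

Compound 4 `CCC1C(=O)N(C)c2cnc(-n3ccc4cc(C(=O)NC5CCCC5)ccc43)nc2N1c1ccn(C)n1` differs from compound 1 in one place: cyclopentyl in place of methyl on an amide-type nitrogen. Among the measured compounds shown here, no measured pair isolates this change, so the expectation rests on compound 1 alone as the starting point. A larger group at this amide-type nitrogen is expected to shift the value at most modestly, in the direction of stronger inhibition, with a real chance of no step beyond the scatter; the expected step from compound 1 to compound 4 is a 1.9-fold lower number from compound 1 to compound 4 (0.28 log units; within the scatter). Compound 4 is therefore estimated at 7000 nM, with a range from 1800 nM to 28000 nM.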

Compound 4, concentration for 50% growth inhibition: 31300 nM
Compound 4: the middle estimate sits 4.5-fold (0.65 log units) below what was measured; measured number outside the range, above it.
By their numbers in this assay, from the lowest: compound 2; then compounds 3 and 1 (each within the scatter of the next); then compound 4.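

Cyclopentyl in place of methyl on the amide-type nitrogen gives the first single-place step in the series: in this assay the change brings a 2.4-fold higher number from compound 1 to compound 4 (0.37 log units; beyond the scatter) and so moves toward weaker inhibition of growth. This amide-type nitrogen is therefore a place where the substituent can change the read-out, although the step is modest. Nothing available bears on why this step occurs.

From the compounds shown here alone, one step from methyl to cyclopentyl does not give a trend, so it remains open whether an ethyl or isopropyl group, or the unsubstituted amide, would fall on the same side of compound 1. Also open, going by these compounds, is whether a chain ending in an amine or a carboxylic acid on this nitrogen would reverse the direction of the step.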